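Compound 2 to compound 4: ethyl to allyl

The source may report more compounds than this note shows. Statements on the series, on what has been measured and on what is new or still open speak of the compounds shown alone.

Compound 2 `CCc1c(OC)nc2nc(-c3nc(C)cs3)cn2c1C` was tested in a functional assay on the whole organism with Rattus norvegicus as the target (a higher number here means that more compound is needed for the effect, a lower number that less compound is needed), where compound 2 reaches only the limit of the assay, > 50 mg/kg, so no number stands for it. Compound 3 `CCc1c(OC)nc2nc(-c3nc(C(F)(F)F)cs3)cn2c1C`, with trifluoromethyl in place of methyl on an aromatic carbon, gives in this assay likewise the limit > 50 mg/kg. Among the compounds with values here, the only measured step, a step that the two limits leave unreadable from compound 2 to compound 3, cannot be sized because both of its ends sit at the limit of > 50 mg/kg in this assay, at which 2 of the 3 values shown sit. Within the data shown here, compound 1 `C=CCc1c(OC)nc2nc(-c3nnc(C)o3)cn2c1C` gives in this assay a number, 10 mg/kg, but it differs from compound 2 in more than one place, so no single step is drawn from it. Compound 4 `C=CCc1c(OC)nc2nc(-c3nc(C)cs3)cn2c1C` is not yet measured; it differs from compound 2 by vinyl in place of methyl on a saturated chain carbon bound to an aromatic carbon, or, cut one bond further out, ethyl to allyl. Among the measured compounds shown here, no measured step covers this change, so the measured pairs give no direction. Compound 4 is therefore expected to stay near the limit, at about 50 mg/kg with a range from 15 mg/kg to 150 mg/kg. The step this estimate means, a number no higher from compound 2 to compound 4 (the limit leaves the size open), is expected to be small.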

Compound 4, minimum effective dose: > 50 mg/kg
Compound 4: a limit, no number; the forecaster's own chance of this, stated with the estimate: 60%; the middle value lies on the limit itself.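

Compound 4 carries the same allyl group as compound 1, so the two differ in one place only: 4-methyl-1,3-thiazol-2-yl in place of 5-methyl-1,3,4-oxadiazol-2-yl. Within the data shown here, this gives the first readable step in this assay, and it shows that with allyl held fixed, this exchange matters: an at least 5.0-fold higher number from compound 1 to compound 4 (0.69 log units; beyond the scatter). Allyl on its own does not bring the 4-methyl-1,3-thiazol-2-yl compound off the limit, and the steps among compound 2, compound 3 and compound 4 cannot be read because all three sit there: the limit of > 50 mg/kg in this assay, at which 3 of the 4 values shown sit.

From the compounds shown here alone, how far past the limit compound 2 and compound 4 lie stays open, so ethyl to allyl has no size here. Also open, going by these compounds, is what a propyl chain or an amine would do on this same carbon.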